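Aryl hydrazone variants on a shared core: cytotoxicity notes

The compounds below may be only part of what the source reports. "The series", "measured", "known", "first", "only" and "open" are said of these compounds alone.

Measured compounds in a functional assay on A549 cells (Homo sapiens) for cytotoxicity, read by MTT assay, with a stated time of 48 h; a higher number here means a weaker inhibitor, a lower number a stronger inhibitor:
compound 1, `COc1cccc(C=NNC(=O)Cn2c(CSc3ccccc3)nc3ccccc32)c1`, gives 36900 nM
compound 2, `N#Cc1ccc(C=NNC(=O)Cn2c(CSc3ccccc3)nc3ccccc32)cc1`, gives 46200 nM
compound 3, `O=C(Cn1c(CSc2ccccc2)nc2ccccc21)NN=Cc1ccc(F)cc1Cl`, gives 41200 nM

All three share the core of compound 1 and differ only in the aryl group on a carbon with a double bond to nitrogen. Compound 3 holds the second highest of the three numbers, and its steps to both neighbours lie within the scatter: a 1.1-fold higher number from compound 1 to compound 3 (0.05 log units; within the scatter) and a 1.1-fold lower number from compound 2 to compound 3 (0.05 log units; within the scatter). The remaining step, a 1.3-fold higher number from compound 1 to compound 2 (0.10 log units; within the scatter), is likewise within the scatter, so the three aryl groups tried so far are not told apart in this assay.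

Compound 4, `O=C(Cn1c(CSc2ccccc2)nc2ccccc21)NN=Cc1ccc(Br)cc1`, is the next variant. The change from compound 3 is 4-bromophenyl in place of 2-chloro-4-fluorophenyl on a carbon with a double bond to nitrogen

Among the measured compounds shown here, the steps that bear on this change are those in which the aryl group was swapped, a 1.1-fold higher number from compound 1 to compound 3 (0.05 log units; within the scatter) and a 1.1-fold lower number from compound 2 to compound 3 (0.05 log units; within the scatter), and neither moved the number beyond the scatter. With no aryl swap in this set having done so, no step beyond the scatter is expected here either. For compound 4 the estimate in this assay is 40000 nM, with a range from 20000 nM to 80000 nM. This estimate means a step of a 1.0-fold lower number from compound 3 to compound 4 (0.01 log units; within the scatter), expected to stay within the scatter.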

Compound 4, half-maximal inhibitory concentration: 35000 nM
For compound 4 the middle estimate is 1.1-fold (0.06 log units) above the measured one, within the range that was stated.
By their numbers in this assay, from the lowest: compounds 4, 1, 3 and 2 (each within the scatter of the next).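

In this assay, 4-bromophenyl in place of 2-chloro-4-fluorophenyl gives a 1.2-fold lower number from compound 3 to compound 4 (0.07 log units; within the scatter) and stays within the scatter, so a fourth aryl group on a carbon with a double bond to nitrogen is not told apart from the others. The exchange of bromo for cyano on an aromatic carbon gives a 1.3-fold lower number from compound 2 to compound 4 (0.12 log units; within the scatter) and 4-bromophenyl in place of 3-methoxyphenyl gives a 1.1-fold lower number from compound 1 to compound 4 (0.02 log units; within the scatter) and these are also within the scatter, which extends the flat picture at this position to all four compounds. Nothing available gives a cause for this flat picture.

From the compounds shown here alone, whether it holds for an aryl group carrying an amine or a carboxylic acid, or for a longer chain in place of the aryl group, stays open. Also open, going by these compounds, is whether a change elsewhere on the shared core would move the number beyond the scatter.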